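From trifluoromethyl to methoxy in an antiproliferative series

This account rests on a few compounds, and the source may have more. Where it says the series, first, only, none or still open, it means among the compounds named here.

Of the compounds shown here, three sharing one core have been tested in a functional assay on Jurkat cells (Homo sapiens) for antiproliferative activity, read by MTT assay, with a stated time of 72 h; a lower number here means a stronger inhibitor, a higher number a weaker inhibitor. Compound 1 `COc1cc(-c2nc(N(C)C)sc2-c2ccc3ccccc3c2)cc(OC)c1OC`, carrying naphthalen-2-yl, gives 836 nM. Compound 2 `COc1cc(-c2nc(N(C)C)sc2-c2ccc(C)cc2)cc(OC)c1OC`, carrying 4-methylphenyl, gives 6660 nM. Compound 3 `COc1cc(-c2nc(N(C)C)sc2-c2ccc(C(F)(F)F)cc2)cc(OC)c1OC`, carrying 4-(trifluoromethyl)phenyl, reads > 10000 nM, which is a limit of the assay and not a number.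

The next compound is compound 4 `COc1ccc(-c2sc(N(C)C)nc2-c2cc(OC)c(OC)c(OC)c2)cc1`, which turns 4-(trifluoromethyl)phenyl into 4-methoxyphenyl: methoxy in place of trifluoromethyl on an aromatic carbon.

For the measured compounds named here, no measured step makes this exact exchange. The closest is the exchange of methyl for trifluoromethyl, an at least 1.5-fold higher number from compound 2 to compound 3 (0.17 log units; that floor lies within the scatter). The replacements of naphthalen-2-yl are larger: an 8.0-fold higher number from compound 1 to compound 2 (0.90 log units; beyond the scatter) and an at least 11-fold higher number from compound 1 to compound 3 (1.07 log units; beyond the scatter). These steps show that changing this aryl group can move the number well beyond the scatter. Going by the values given here, compound 2, with its single small group on the same kind of ring, is the nearest guide at 6660 nM, so a number near that of compound 2 or somewhat lower seems likely.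

The expected change in this assay is an at least 4.0-fold lower number from compound 3 to compound 4 (0.60 log units; beyond the scatter), toward a stronger inhibitor. The estimate for compound 4 is 2500 nM, with an expected range from 300 nM to 10000 nM.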

Compound 4, half-maximal inhibitory concentration: 7600 nM
Compound 4: the middle estimate sits 3.0-fold (0.48 log units) below what was measured; the range from low to high includes it.
By their numbers in this assay, from the lowest: compound 1; then compounds 2 and 4 (each within the scatter of the next). At a limit, above all of these: compound 3.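

In this assay, methoxy and methyl on this ring cannot be told apart, a 1.1-fold higher number from compound 2 to compound 4 (0.06 log units; within the scatter), while the replacement of the larger aryl group remains a clear change, a 9.1-fold higher number from compound 1 to compound 4 (0.96 log units; beyond the scatter); compounds 2 and 4 thus sit together, apart from compound 1. Compound 3 reads > 10000 nM, which is a limit of the assay and not a number. The step of an at least 1.3-fold lower number from compound 3 to compound 4 (0.11 log units; that floor lies within the scatter) therefore gives only a floor, so it cannot be said whether methoxy truly improves on trifluoromethyl, and the true size of this exchange stays unknown: the limit of > 10000 nM in this assay, at which 1 of the 4 values shown sits.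

The compounds shown leave open whether any small group at this place can bring a single-ring compound close to compound 1, for example a hydroxyl group, a chlorine atom or an amine in place of methoxy. They also leave open whether a longer chain, such as butyl, on the same ring would move the number beyond the scatter, or whether the second fused ring of naphthalen-2-yl is needed for the lower value.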